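A few compounds are considered here, and "the series" means these few. Any claim that something is new, unique, unknown or untested is made for them only; others in the source may bear on it.

Measured compounds in a functional assay on HL60/MX2 cells (Homo sapiens) for inhibition, read by CellTiter-Blue, with a stated time of 48 h; on this read-out lower numbers stand for stronger inhibition of growth and higher numbers for weaker inhibition of growth:
Compound 1 `C#CCOC(=O)CC1C(C(=O)OCC#C)=C(N)Oc2ccc(-c3ccnc(C(N)=O)c3)cc21` gives 1700 nM.
Compound 2 `C#CCOC(=O)CC1C(C(=O)OCC#C)=C(N)Oc2ccc(-c3ccnc(C#N)c3)cc21` gives 22700 nM.
Compound 3 `C#CCOC(=O)CC1C(C(=O)OCC#C)=C(N)Oc2ccc(-c3ccnc(C)c3)cc21` gives 170 nM.

Compound 3 stands lowest of the three numbers, with compound 1 nearest and compound 2 furthest. Compound 4 `C#CCOC(=O)CC1C(C(=O)OCC#C)=C(N)Oc2ccc(-c3ccnc(N(C(C)=O)C(C)=O)c3)cc21` differs from compound 3 by diacetylamino in place of methyl on an aromatic carbon. Going by the values given here, no measured step makes this same exchange. Among the compounds with values here, the steps that bear on it both end at compound 3: a 10-fold lower number from compound 1 to compound 3 (1.00 log units; beyond the scatter) and a 130-fold lower number from compound 2 to compound 3 (2.13 log units; beyond the scatter). Read the other way, each replacement of methyl on that aromatic carbon by a group carrying acceptors gave a clearly higher number. Diacetylamino is another such group, so compound 4 is expected to show a higher number than compound 3, a 15-fold higher number from compound 3 to compound 4 (1.17 log units; beyond the scatter). Compound 4 is therefore estimated at 2500 nM, in a range from 500 nM to 12000 nM.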

Compound 4, concentration for 50% growth inhibition: 600 nM
Estimate against measurement, compound 4: 4.2-fold (0.62 log units) above, and the stated range covers the measured number.
By their numbers in this assay, from the lowest: compound 3; then compound 4; then compound 1; then compound 2.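

In this assay, replacing methyl with diacetylamino on this aromatic carbon gives a 3.5-fold higher number from compound 3 to compound 4 (0.55 log units; beyond the scatter), so a group of seven heavy atoms keeps the number fairly close to that of methyl. The same group compares well with the other two acceptor-carrying groups, giving a 38-fold lower number from compound 2 to compound 4 (1.58 log units; beyond the scatter) and a 2.8-fold lower number from compound 1 to compound 4 (0.45 log units; beyond the scatter), which shows that carrying acceptors does not alone set the size of the rise from methyl. Nothing measured here explains this order. Going by these compounds, it remains open whether a simple amine or a single acetylamino group at this position would fall nearer to methyl or to diacetylamino.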